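The source may report more compounds than this note shows. Statements on the series, on what has been measured and on what is new or still open speak of the compounds shown alone.

Of the compounds shown here, two sharing one core have been tested in a functional assay on FM3A cells (Mus musculus) for antiproliferative activity; a lower number here means a stronger inhibitor, a higher number a weaker inhibitor. Compound 1, `COc1cc(C(=O)c2sc(-c3ccc(-c4ccccc4)cc3)cc2N)cc(OC)c1OC`, reports only a limit in this assay, namely > 10000 nM, which marks the edge of what the assay reads rather than a number. Compound 2, `COc1cc(C(=O)c2sc(-c3ccccc3Cl)cc2N)cc(OC)c1OC`, gives 34 nM in this assay, and this is the only number shown. Compound 3, `COc1cc(C(=O)c2sc(-c3ccc(C(F)(F)F)cc3)cc2N)cc(OC)c1OC`, has not yet been measured. It differs from compound 2 in one place: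

4-(trifluoromethyl)phenyl in place of 2-chlorophenyl on an aromatic carbon

Going by the values given here, no step between measured compounds can be computed here, so the size of the change in this assay from compound 2 to compound 3 is not given by the data. The expected step is a 12-fold higher number from compound 2 to compound 3 (1.07 log units; beyond the scatter), a loss of potency beyond the usual scatter. Compound 3 is estimated at 400 nM in this assay, with a range from 60 nM to 5000 nM.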

Compound 3, half-maximal inhibitory concentration: 540 nM
Beside the measured number, compound 3's estimate is 1.4-fold (0.13 log units) below it; measured number inside the range.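

In this assay, 4-(trifluoromethyl)phenyl in place of 2-chlorophenyl, on the aromatic carbon next to the ring sulfur, gives a 16-fold higher number from compound 2 to compound 3 (1.20 log units; beyond the scatter), so the group at this position strongly affects the read-out. Trifluoromethyl in place of the outer phenyl gives an at least 18-fold lower number from compound 1 to compound 3 (1.26 log units; beyond the scatter), which places compound 3 between the two earlier results and shows that a group on the 4 position of this phenyl ring can still leave a measurable value. The size of that second step has only a floor, because compound 1 reports a limit and not a number: the limit of > 10000 nM in this assay, at which 1 of the 3 values shown sits.

The step from compound 2 to compound 3 changes both the group on the phenyl ring and where it sits, and the compounds shown do not separate these two changes. From the compounds shown here alone, how 4-chlorophenyl or plain phenyl would read at this position remains open.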